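This account rests on a few compounds, and the source may have more. Where it says the series, first, only, none or still open, it means among the compounds named here.

Measured compounds so far:
Compound 1, `OCc1cc(O)c(O)c(Br)c1`, gives "not determined" (no result reported) in a functional assay on HCT-116 cells (Homo sapiens) for cytotoxicity, read by MTT assay, with a stated time of 96 h (on this read-out higher numbers stand for weaker inhibition and lower numbers for stronger inhibition), so no result is reported for it.
Compound 2, `OCc1cc(Br)c(O)c(O)c1Br`, gives 21400 nM in this assay.
Compound 3, `OCc1cc(O)c(O)c(Br)c1Br`, gives 20400 nM in this assay.

These three compounds share one small core, a benzene ring bearing a hydroxymethyl group, two hydroxy groups and bromine, with the substituents arranged differently from one to the next. Compound 1 brings no number, so compound 2 can be set only against compound 3: the two values differ by less than the usual scatter of repeated measurements, so nothing separates them, and compound 2 simply gives a weak result in this assay.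

Compound 4, `CCCOCc1cc(Br)c(O)c(O)c1Br`, is built from compound 2 by a single change, (propyl in place of hydrogen on an oxygen on a saturated carbon). The hydroxymethyl group thus becomes a propoxymethyl group, while the rest of compound 2 is kept. Among the compounds with values here, no measured pair shows what this kind of change does in this assay, so there is no step to lean on; the expectation rests on the value of compound 2 alone.

With only that to go on, the step of a 1.2-fold lower number from compound 2 to compound 4 (0.08 log units; within the scatter) is expected to be small, most likely none beyond the scatter, in either direction. Compound 4 is therefore estimated at 18000 nM, with a range from 6000 nM to 55000 nM.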

Compound 4, half-maximal inhibitory concentration: 800 nM
Compound 4: middle estimate off by 23-fold (1.35 log units), on the high side; the whole stated range lies above it.
By their numbers in this assay, from the lowest: compound 4; then compounds 3 and 2 (each within the scatter of the next).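

The oxygen of the hydroxymethyl group turns out to be a highly sensitive place in this assay: putting propyl in place of its hydrogen, with the rest of the molecule kept, brings a 27-fold lower number from compound 2 to compound 4 (1.43 log units; beyond the scatter), and this lower number stands for stronger inhibition. The earlier compounds shown here could not show this, since they differ only in how the same substituents are arranged on the shared core, and they offer no single-change step to read. This first step shows that the hydroxymethyl group need not stay free for activity in these cells, and that going from hydroxymethyl to propoxymethyl alone can lift a weak compound well clear of the scatter, although nothing available here accounts for the size of this gain.

Going by these compounds, whether propyl is the best choice stays open, since a methyl group, a longer chain such as hexyl, an amine or a carboxylic acid in its place might give a smaller step, a larger one or none at all. On these data alone, it is equally open whether the same change would give a similar step on compound 3, where the bromines are arranged differently.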